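The source may report more compounds than this note shows. Statements on the series, on what has been measured and on what is new or still open speak of the compounds shown alone.

The shared core carries a sulfonyl group and an amide, and the three measured compounds differ only in what hangs on the amide-type nitrogen. In an ADME assay on MT4 cells (Homo sapiens) for cytotoxicity, read by MTT assay (on this read-out lower numbers stand for higher toxicity in this test and higher numbers for lower toxicity in this test), compound 1 `Cc1cc(C)cc(S(=O)(=O)c2c(C(=O)NCc3cccc(F)c3F)[nH]c3ccc(Cl)cc23)c1` gives only a limit, > 51100 nM, so no number is known for it. Compound 2 `Cc1cc(C)cc(S(=O)(=O)c2c(C(=O)NCC(=O)NCCn3c(C)cnc3[N+](=O)[O-])[nH]c3ccc(Cl)cc23)c1` gives 24500 nM in this assay. Compound 3 `Cc1cc(C)cc(S(=O)(=O)c2c(C(=O)NC(C)C(=O)NCc3ccncc3)[nH]c3ccc(Cl)cc23)c1` gives 19500 nM, which stands as the lowest of the two numbers on hand, although compound 2 lies within the scatter of it, so the two cannot be told apart. Among the measured compounds shown here, the single measured step, an at least 2.6-fold lower number from compound 1 to compound 3 (0.41 log units; beyond the scatter), is the only change on this nitrogen with a known size, and it rests on the limit (the limit of > 51100 nM in this assay, at which 1 of the 3 values shown sits).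

Compound 4 `Cc1cc(C)cc(S(=O)(=O)c2c(C(=O)NCC(=O)NCc3ccncn3)[nH]c3ccc(Cl)cc23)c1` has not yet been measured. It differs from compound 3 by a group of 11 heavy atoms (7 carbon, 3 nitrogen, 1 oxygen; one six-membered aromatic ring with 2 hetero atoms) in place of a group of 12 heavy atoms (9 carbon, 2 nitrogen, 1 oxygen; one six-membered aromatic ring with 1 hetero atom), on an amide-type nitrogen. This is a smaller change than the measured step: the chain with its amide and a six-membered aromatic ring stays, and one six-membered aromatic ring with 1 hetero atom is exchanged for one with 2 hetero atoms. Compound 2, which also carries a chain with an amide and a heteroaromatic ring, sits within the scatter of compound 3. The expected step is therefore a 1.1-fold higher number from compound 3 to compound 4 (0.05 log units; within the scatter), within the scatter. Compound 4 is estimated at 22000 nM, with a range from 10000 nM to 50000 nM.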

Compound 4, half-maximal cytotoxic concentration: > 48800 nM
Compound 4: a limit, no number; the forecaster's own chance of this, stated with the estimate: 15%; middle value at least 2.2-fold (0.34 log units) from the limit.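

Exchanging the group with a six-membered aromatic ring with 1 hetero atom for the one whose six-membered aromatic ring has 2 hetero atoms is not a silent change on this amide-type nitrogen: it gives an at least 2.5-fold higher number from compound 3 to compound 4 (0.39 log units; beyond the scatter) in this assay and so points to lower toxicity in this test. A chain with an amide on this nitrogen therefore does not by itself go with numbers as low as those of compound 2 and compound 3, although the step of an at least 1.9-fold higher number from compound 2 to compound 4 (0.29 log units; that floor lies within the scatter) for the exchange of the five-membered ring group has only a floor inside the scatter and does not firmly part that pair. Compound 4 gives a limit and not a number, as compound 1 does, and the step between those two cannot be read.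

The exchange from compound 3 also alters the group as a whole, so the compounds shown do not tell whether the added ring nitrogen or the rest of the change carries the step. From the compounds shown here alone, it also stays open how a carboxylic acid or a simple amine at the end of this chain would read in this test.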